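Swapping tert-Butoxycarbonyl for (4-Methylphenyl)sulfonyl on a Ring Amine

The source may hold more compounds than are shown below. What is called first, only, known or untested is meant among the compounds shown, and "the series" means these compounds.

Compound 1 `CCCn1c(SCc2cccc(OC)c2)nc2c1c(=O)[nH]c(=O)n2C`: 34.2%
Compound 2 `Cn1cnc2c1c(=O)n(CC(=O)N1CCN(C(=O)OC(C)(C)C)CC1)c(=O)n2C`: 20%

In a functional assay on MGC-803 cells (Homo sapiens) for inhibition, read by MTT assay, with a stated time of 48 h, tested at 20 uM (on this read-out higher numbers stand for more inhibition at the one concentration tested (going by the name of the read-out) and lower numbers for less inhibition), compound 2 gives 20%, the lowest of the two numbers shown. Compound 1 gives 34.2%, a gap beyond the scatter. Going by the values given here, no pair of measured compounds differing in one place is available, so nothing is known here about a change of this kind. Compound 3 `Cc1ccc(S(=O)(=O)N2CCN(C(=O)Cn3c(=O)c4c(ncn4C)n(C)c3=O)CC2)cc1` differs from compound 2 as follows: (4-methylphenyl)sulfonyl in place of tert-butoxycarbonyl on an amine nitrogen in a ring. The step of a number 5 percentage points higher from compound 2 to compound 3 (within the scatter) is expected to be small, within the scatter or a little upward. Compound 3 is expected to give 25%, within 10% to 45%.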

Compound 3, a percentage reported as inhibition, at one concentration (the size of the read-out at that concentration, not a potency): 20.1%
Beside the measured number, compound 3's estimate is 4.9 percentage points above it, and the stated range covers the measured number.
By their numbers in this assay, from the lowest: compounds 2 and 3 (each within the scatter of the next); then compound 1.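

In this assay, (4-methylphenyl)sulfonyl in place of tert-butoxycarbonyl on an amine nitrogen in a ring gives a number 0.1 percentage points higher from compound 2 to compound 3 (within the scatter). This position therefore accepts a group with a six-membered aromatic ring of carbon only, and more heavy atoms, with the two compounds remaining within the scatter of each other at the one concentration tested. No measurement at hand gives a reason for this result. As far as these compounds go, it remains open whether a free amine, an acetyl group or a benzyl group on that nitrogen would stand apart from these two.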